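From a Dimethoxyphenyl Dienone to Its Furan Analogue

This account rests on a few compounds, and the source may have more. Where it says the series, first, only, none or still open, it means among the compounds named here.

Of the compounds shown here, two have so far been measured in a functional assay on COLO 205 cells (Homo sapiens) for inhibition, read by sulforhodamine B assay, with a stated time of 48 h, tested at 50 uM; a lower number here means less inhibition of growth, a higher number more inhibition of growth at the concentration tested. Compound 1 `COc1ccccc1/C=C/C(=O)/C=C/c1ccc(OCc2cn(CCCOc3cc(=O)oc4ccccc34)nn2)c(OC)c1` gives 57%. Compound 2 `COc1ccc(/C=C/C(=O)/C=C/c2ccc(OCc3cn(CCOc4cc(=O)oc5ccccc45)nn3)c(OC)c2)cc1OC` gives 80% in this assay, the higher of the two numbers, and its gap to compound 1 lies beyond the usual scatter of repeated measurements. The two measured compounds differ from each other in more than one place, so no single isolated step can be read from them.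

Compound 3 `COc1cc(/C=C/C(=O)/C=C/c2ccco2)ccc1OCc1cn(CCOc2cc(=O)oc3ccccc23)nn1` has not yet been measured. It differs from compound 2 in one place: furan-2-yl in place of 3,4-dimethoxyphenyl on a double-bonded chain carbon bound to a double-bonded chain carbon. The measured compounds offer no direct guide to such a change, so the expectation rests on the shared core alone. The step from compound 2 to compound 3 is expected to be a drop of about a number 25 percentage points lower from compound 2 to compound 3 (beyond the scatter), beyond the scatter. Compound 3 is therefore expected to give about 55%, within a range from 30% to 80%.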

Compound 3, percent growth inhibition at one concentration: 68%
Estimate against measurement, compound 3: 13 percentage points below; the range from low to high includes it.
By their numbers in this assay, from the lowest: compound 1; then compound 3; then compound 2.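

Among the compounds shown here, this is the first step that can be read at a single place. In this assay, furan-2-yl in place of 3,4-dimethoxyphenyl on a double-bonded chain carbon bound to a double-bonded chain carbon gives a number 12 percentage points lower from compound 2 to compound 3 (beyond the scatter), so the change has a modest measurable cost, yet compound 3 still reaches 68%. No evidence is available to explain this step.

This single pair cannot separate the change of ring from the loss of the two methoxy groups. Plain phenyl, 4-methoxyphenyl or thiophen-2-yl at this place would be needed to tell these apart, and the read-out at one concentration leaves open how compound 2 and compound 3 compare across a range of concentrations.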